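Restoring the Carbamoyl with an Aminopropyl Chain

The compounds below may be only part of what the source reports. "The series", "measured", "known", "first", "only" and "open" are said of these compounds alone.

Of the compounds shown here, two sharing one core have been measured so far. Compound 1 `NC(=O)c1ccc(-c2cc(C(=O)O)cc(-c3cn(-c4ccc(C(F)(F)F)cc4)nn3)c2)cc1` gives 500 nM in an assay on isolated protein for binding affinity to Sigma non-opioid intracellular receptor 1 (Homo sapiens); on this read-out lower numbers stand for stronger inhibition and higher numbers for weaker inhibition. Among the measured compounds shown here, compound 2 `O=C(O)c1cc(-c2ccc(C3CCNCC3)cc2)cc(-c2cn(-c3ccc(C(F)(F)F)cc3)nn2)c1` gives 1480 nM in this assay, the highest of the two numbers, and the only step bearing on it is a 3.0-fold higher number from compound 1 to compound 2 (0.47 log units; beyond the scatter). Compound 3 `NCCCNC(=O)c1ccc(-c2cc(C(=O)O)cc(-c3cn(-c4ccc(C(F)(F)F)cc4)nn3)c2)cc1` is not yet measured; it differs from compound 2 in one place: (3-aminopropyl)carbamoyl in place of piperidin-4-yl on an aromatic carbon. The carbamoyl that compound 1 carries thus returns, now extended by a three-carbon chain ending in an amine. For the measured compounds named here, because compound 1 gives 500 nM while compound 2 gives 1480 nM, the expected move is back toward a lower number, though the added chain has no precedent among the measured pairs. The estimate for compound 3 is 600 nM, with a range from 250 nM to 1500 nM, meaning an expected step of a 2.5-fold lower number from compound 2 to compound 3 (0.39 log units; beyond the scatter).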

Compound 3, inhibition constant: 1110 nM
Beside the measured number, compound 3's estimate is 1.9-fold (0.27 log units) below it, within the range that was stated.
By their numbers in this assay, from the lowest: compound 1; then compounds 3 and 2 (each within the scatter of the next).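

In this assay the open (3-aminopropyl)carbamoyl chain in place of the piperidin-4-yl ring gives a 1.3-fold lower number from compound 2 to compound 3 (0.12 log units; within the scatter) and so, at this place para to a large group, the data do not separate these two amine-bearing groups, even though one has a ring and the other has none. Putting 3-aminopropyl on the amide nitrogen of compound 1 gives a 2.2-fold higher number from compound 1 to compound 3 (0.35 log units; beyond the scatter) and this shows that the carbamoyl alone does not bring back the value of compound 1 once that nitrogen carries the chain.

On these data alone, it remains open whether a shorter 2-aminoethyl chain, or a three-carbon chain ending in a hydroxyl or a carboxylic acid instead of an amine, would fall nearer compound 1 or compound 3. No measured evidence is available to explain either step.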